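Extending an Ethyl Chain to Propyl on the Shared Core

The compounds below may be only part of what the source reports. "The series", "measured", "known", "first", "only" and "open" are said of these compounds alone.

Compound 1 `Cc1ccccc1NS(=O)(=O)c1ccc(NC(=O)NCCCCl)cc1` and compound 2 `CCc1ccccc1NS(=O)(=O)c1ccc(NC(=O)NCCCCl)cc1` share one core and differ in a single small group on the outer ring. In a functional assay on M21 cells (Homo sapiens) for cytotoxicity, read by sulforhodamine B assay, with a stated time of 48 h (on this read-out lower numbers stand for stronger inhibition and higher numbers for weaker inhibition), compound 1 gives only a limit of the assay, > 200000 nM. Compound 2 likewise gives only a limit, > 200000 nM. The step that the two limits leave unreadable from compound 1 to compound 2 therefore cannot be read, because both values sit at the limit of > 200000 nM in this assay, at which 2 of the 2 values shown sit. Compound 3 `CCCc1ccccc1NS(=O)(=O)c1ccc(NC(=O)NCCCCl)cc1` continues the same series: methyl in place of hydrogen on a saturated chain carbon, two bonds along the chain from an aromatic carbon. For the measured compounds named here, the only measured step that bears on this change is the unreadable one just described, so the data give neither a direction nor a size; what they do show is that two chain lengths on this position both stayed at the limit. Compound 3 is therefore expected to remain at that limit as well, with the step that the limit leaves unreadable from compound 2 to compound 3 expected to be no step beyond the scatter. The estimate for compound 3 in this assay is 250000 nM, with a range from 100000 nM to 600000 nM.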

Compound 3, half-maximal inhibitory concentration: 38000 nM
For compound 3 the middle estimate is 6.6-fold (0.82 log units) above the measured one; the whole stated range lies above it.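

In this assay, for the compounds shown here, the position on the outer ring turns out not to be silent: replacing ethyl with propyl gives an at least 5.2-fold lower number from compound 2 to compound 3 (0.72 log units; beyond the scatter), and compound 3 is the first of the three to yield a value that is not a limit. Set against the methyl member of the series, the 2-propylphenyl group gives an at least 5.2-fold lower number from compound 1 to compound 3 (0.72 log units; beyond the scatter), so one added carbon at this place separates a readable value from the limit. The true size of both steps stays open on one side, because each starts from a limit of the assay: the limit of > 200000 nM in this assay, at which 2 of the 3 values shown sit.

The compounds shown leave open whether a butyl or longer chain at this place would lower the number further or lose the gain. They also leave open whether a branched isopropyl group, or a propyl chain ending in an amine, would behave like the straight propyl chain.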